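A few compounds are considered here, and "the series" means these few. Any claim that something is new, unique, unknown or untested is made for them only; others in the source may bear on it.

Three chalcones sharing one core have been tested in a functional assay on HeLa cells (Homo sapiens) for cytotoxicity, read by MTT assay; on this read-out higher numbers stand for weaker inhibition and lower numbers for stronger inhibition. Compound 1 `COc1cc(O)cc(O)c1C(=O)/C=C/c1ccc(O)cc1` gives 5200 nM. Compound 2 `COc1cc(O)c(CC=C(C)C)c(O)c1C(=O)/C=C/c1cccc(O)c1` gives 4800 nM. Compound 3 `COc1cc(O)c(CC=C(C)C)c(O)c1C(=O)/C=C/c1ccc(O)c(O)c1` gives 2500 nM, the lowest of the three numbers, though the step of a 1.9-fold lower number from compound 2 to compound 3 (0.28 log units; within the scatter) lies within the scatter, so compounds 2 and 3 cannot be ranked against each other; compound 3 does stand apart from compound 1, whose number is higher by a margin beyond the scatter.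

The next compound, compound 4 `COc1cc(O)cc(O)c1C(=O)/C=C/c1ccc(O)c(O)c1`, differs from compound 3 in a single place: hydrogen in place of 3-methylbut-2-en-1-yl on an aromatic carbon. Among the measured compounds shown here, no measured pair differs in exactly this way, so the size of this step is not known from the data. For the measured compounds named here, compound 4 is also compound 1 with a hydroxy group added, and the one measured step that adds a hydroxy group, from compound 2 to compound 3, was within the scatter. The expectation is therefore that compound 4 lands between compound 1 and compound 3, so that the step of a 1.6-fold higher number from compound 3 to compound 4 (0.20 log units; within the scatter) from compound 3 is expected to be a modest rise in the number. Compound 4 is estimated at 4000 nM in this assay, with a likely range from 2000 nM to 8000 nM.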

Compound 4, half-maximal inhibitory concentration: 14800 nM
Estimate against measurement, compound 4: 3.7-fold (0.57 log units) below; the measured number lies above the stated range.
By their numbers in this assay, from the lowest: compounds 3, 2 and 1 (each within the scatter of the next, the first and the last beyond it); then compound 4.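

Taking away the 3-methylbut-2-en-1-yl group gives the first reading of a change at this position, an aromatic carbon ortho to two hydroxy groups and para to a methoxy group, and in this assay it gives the largest step in the set: a 5.9-fold higher number from compound 3 to compound 4 (0.77 log units; beyond the scatter). Adding a hydroxy group in place of hydrogen, which stayed within the scatter on the earlier pair, here raises the number instead, with a 2.8-fold higher number from compound 1 to compound 4 (0.45 log units; beyond the scatter). The same kind of change therefore cannot be carried from one core to another, as its size and even its direction differ between the two pairs: the same change on two cores in this assay, a 1.9-fold lower number (0.28 log units; within the scatter) from compound 2 to compound 3 and a 2.8-fold higher number (0.45 log units; beyond the scatter) from compound 1 to compound 4, 5.5-fold (0.74 log units) apart, beyond the scatter of two such steps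

The compounds shown leave open whether this position needs the 3-methylbut-2-en-1-yl group itself or would accept another carbon chain, such as a methyl group, a saturated 3-methylbutyl chain or a longer geranyl chain, and how an amine would behave there. On these data alone, it also remains open whether taking this group away from the core of compound 2 would give a step of the same size.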